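A few compounds are considered here, and "the series" means these few. Any claim that something is new, unique, unknown or untested is made for them only; others in the source may bear on it.

Compound 1 `CCOC(=O)c1cc(-c2cc(OC)c(OC)c(OC)c2)c(-c2ccc(OC)c([N+](=O)[O-])c2)s1` gives 18100 nM
Compound 2 `COc1ccc(-c2sc(C(=O)O)cc2-c2cc(OC)c(OC)c(OC)c2)cc1` gives 7800 nM

In a functional assay on SGC-7901 cells (Homo sapiens) for antiproliferative activity, read by MTT assay, with a stated time of 72 h (a lower number here means a stronger inhibitor, a higher number a weaker inhibitor), compound 2 at 7800 nM stands lowest of the two numbers, and the gap to compound 1 lies beyond the scatter. Compound 3 `COc1ccc(-c2sc(C(=O)O)cc2-c2cc(OC)c(OC)c(OC)c2)cc1[N+](=O)[O-]` comes from compound 2 by nitro in place of hydrogen on an aromatic carbon with the nitro ortho to a methoxy group. Within the data shown here, no step between measured compounds isolates this change. Compound 1 at 18100 nM also carries a nitro and holds the higher number, so a modest move toward a higher number in this assay is expected. The estimated step of a 1.4-fold higher number from compound 2 to compound 3 (0.15 log units; within the scatter) is small and uncertain in size. The estimate for compound 3 is 11000 nM within an expected range of 3500 nM to 30000 nM for now.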

Compound 3, half-maximal inhibitory concentration: 23300 nM
Compound 3: middle estimate off by 2.1-fold (0.33 log units), on the low side; low and high end bracket the measured number.
By their numbers in this assay, from the lowest: compound 2; then compounds 1 and 3 (each within the scatter of the next).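

In this assay, among these compounds, nitro in place of hydrogen on an aromatic carbon, ortho to a methoxy group, gives a 3.0-fold higher number from compound 2 to compound 3 (0.48 log units; beyond the scatter), the first reading of a single change at this position. Hydrogen in place of ethyl on an oxygen next to a carbonyl group gives a 1.3-fold higher number from compound 1 to compound 3 (0.11 log units; within the scatter), so this exchange shows no separable difference with the nitro present. No measured evidence bears on the cause of either step. From the compounds shown here alone, whether an amine or a methyl group at this position would give a number nearer that of compound 2 remains open. Going by these compounds, the size of the nitro step with ethyl on that oxygen also remains open.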